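This account rests on a few compounds, and the source may have more. Where it says the series, first, only, none or still open, it means among the compounds named here.

Measured so far in a functional assay on PC-3 cells (Homo sapiens) for cytotoxicity, read by MTT assay; on this read-out higher numbers stand for weaker inhibition and lower numbers for stronger inhibition:

Compound 1 `c1ccc(-c2nnc(-c3c[nH]c4ccccc34)o2)cc1` — > 1000000 nM (a limit of the assay, not a number)
Compound 2 `Clc1ccc(-c2nnc(-c3c[nH]c4ccccc34)o2)cc1` — 41600 nM

Compound 1 reaches only a limit in this assay, (the limit of > 1000000 nM in this assay, at which 1 of the 2 values shown sits). Within the data shown here, compound 2 is therefore the only compound of the series with a number in this assay. Among the measured compounds shown here, the step of an at least 24-fold lower number from compound 1 to compound 2 (1.38 log units; beyond the scatter) is the single measured step, and it concerns the phenyl ring that compound 3 gives up.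

Compound 3 `Cc1nnc(-c2c[nH]c3ccccc23)o1` differs from compound 2 by methyl in place of 4-chlorophenyl on an aromatic carbon of the shared core. Since compound 1, which lacks only the chloro of compound 2, already falls to the limit, removing the whole 4-chlorophenyl is expected to cost at least as much, with a large upward step a 9.6-fold higher number from compound 2 to compound 3 (0.98 log units; beyond the scatter). For compound 3 the estimate is 400000 nM, with the range 80000 nM to 2000000 nM; a limit rather than a number is quite possible.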

Compound 3, half-maximal inhibitory concentration: > 1000000 nM
Compound 3 gave a limit, no number; the forecaster's own chance of this, stated with the estimate: 45%; at least 2.5-fold (0.39 log units) between middle value and limit.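

In this assay, methyl in place of 4-chlorophenyl on this aromatic carbon gives an at least 24-fold higher number from compound 2 to compound 3 (1.38 log units; beyond the scatter), so a small group here does not keep the activity seen with compound 2. Compound 3 gives > 1000000 nM, which is a limit of the assay and not a number. Compound 1 and compound 3 cannot be ranked against each other, and the step between them cannot be read, because both stand at the same limit: the limit of > 1000000 nM in this assay, at which 2 of the 3 values shown sit.

Among these compounds, with compound 2 as the only compound carrying a number, it stays open whether the chloro itself matters or whether another para-free replacement would serve equally. Also open, going by these compounds, is what a 4-methoxyphenyl, a 4-aminophenyl or a longer chain such as hexyl on this carbon would give.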